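From bromo to fluoro: a small swap on the shared core

This account rests on a few compounds, and the source may have more. Where it says the series, first, only, none or still open, it means among the compounds named here.

Of the compounds shown here, two sharing one core have been measured so far in a functional assay on MCF7 cells (Homo sapiens) for antiproliferative activity, read by MTT assay, with a stated time of 72 h; on this read-out higher numbers stand for weaker inhibition and lower numbers for stronger inhibition. Compound 1 (`C/C(=N\NC(=O)c1cccc(S(=O)(=O)N2CCOCC2)c1)c1ccccc1O`) gives 5400 nM, and compound 2 (`C/C(=N\NC(=O)c1cccc(S(=O)(=O)N2CCOCC2)c1)c1cc(Br)ccc1O`) gives 7830 nM. These two numbers lie within the usual scatter of repeated measurements, so compound 2 stands level with compound 1 and not apart from it.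

Compound 3 (`C/C(=N\NC(=O)c1cccc(S(=O)(=O)N2CCOCC2)c1)c1cc(F)ccc1O`) has fluoro in place of bromo on an aromatic carbon, turning the 5-bromo-2-hydroxyphenyl into 5-fluoro-2-hydroxyphenyl: fluoro in place of bromo on an aromatic carbon. Among the compounds with values here, only one measured step bears on this change: a 1.5-fold higher number from compound 1 to compound 2 (0.16 log units; within the scatter), with bromo in place of hydrogen on that same carbon. That step stays within the scatter. Compound 3 puts a third group on this carbon, and one step is thin evidence, so the forecast stays cautious: no change beyond the scatter is expected in this assay, in either direction. The expected step is a 1.3-fold lower number from compound 2 to compound 3 (0.10 log units; within the scatter), which is also within the scatter. For compound 3 the estimated value is 6200 nM, with an expected range from 2800 nM to 13000 nM.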

Compound 3, half-maximal inhibitory concentration: 6650 nM
Estimate against measurement, compound 3: 1.1-fold (0.03 log units) below; the range from low to high includes it.
By their numbers in this assay, from the lowest: compounds 1, 3 and 2 (each within the scatter of the next).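

In this assay, the swap of one halogen for the other gives a 1.2-fold lower number from compound 2 to compound 3 (0.07 log units; within the scatter), and setting fluoro against plain hydrogen on the same carbon gives a 1.2-fold higher number from compound 1 to compound 3 (0.09 log units; within the scatter). With compound 3 measured, this carbon, para to the hydroxy group, has now carried hydrogen, bromo and fluoro, and all three compounds stand level, so the result no longer rests on a single step and neither halogen separates from hydrogen or from the other halogen. No supporting measurement is available to explain why these three compounds stand level.

Going by these compounds, all of this covers only a single atom at a single place on the shared core, so it remains open whether a larger or different kind of group on this carbon, such as an amine, a carboxylic acid or a longer carbon chain, would move the number beyond the scatter. On these data alone, it also remains open whether fluoro or bromo on another carbon of this six-membered aromatic ring would behave in the same way.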